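Trimming the sulfonyl chain once more in a triazine series

The compounds below may be only part of what the source reports. "The series", "measured", "known", "first", "only" and "open" are said of these compounds alone.

Compound 2 `CCS(=O)(=O)NC(=O)c1ccc(Nc2nc(NC3(c4ccc(Cl)cc4)CC3)nc(OCC(F)(F)F)n2)cc1` gives 85% in an ADME assay on microsomes from liver (Rattus norvegicus) for metabolic stability, with a stated time of 10 min (on this read-out lower numbers stand for a less stable compound and higher numbers for a more stable compound), the lowest of the three measured numbers. Compound 1 `CC(C)NCCS(=O)(=O)NC(=O)c1ccc(Nc2nc(NC3(c4ccc(Cl)cc4)CC3)nc(OCC(F)(F)F)n2)cc1` gives 100% and compound 3 `CNC(=O)NCCS(=O)(=O)NC(=O)c1ccc(Nc2nc(NC3(c4ccc(Cl)cc4)CC3)nc(OCC(F)(F)F)n2)cc1` gives 100% in this assay. The unmeasured compound 4 `CS(=O)(=O)NC(=O)c1ccc(Nc2nc(NC3(c4ccc(Cl)cc4)CC3)nc(OCC(F)(F)F)n2)cc1` differs from compound 2 by hydrogen in place of methyl on a saturated chain carbon bound to a sulfonyl sulfur, that is, ethylsulfonyl to methylsulfonyl. The relevant measured steps both remove a group from the same chain: a number 15 percentage points lower from compound 1 to compound 2 (beyond the scatter) and, read in reverse, a number 15 percentage points higher from compound 2 to compound 3 (beyond the scatter). Each shortening of the chain cost compound 2 a modest amount, while no change at the digits printed from compound 1 to compound 3 (within the scatter). Losing one further carbon is a smaller change, so for compound 4 a small drop or no change beyond the scatter is expected, a number 5 percentage points lower from compound 2 to compound 4 (within the scatter). Compound 4 is therefore estimated at 80%, within 65% to 95%.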

Compound 4, percent of the compound remaining: 85%
Estimate against measurement, compound 4: 5 percentage points below; the range from low to high includes it.
By their numbers in this assay, from the lowest: compounds 2 and 4 (each within the scatter of the next); then compounds 1 and 3 (each within the scatter of the next).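

In this assay the change from ethylsulfonyl to methylsulfonyl gives no change at the digits printed from compound 2 to compound 4 (within the scatter) and so adds nothing beyond the scatter at this position. The steps of a number 15 percentage points lower from compound 3 to compound 4 (beyond the scatter) and a number 15 percentage points lower from compound 1 to compound 4 (beyond the scatter) match in size those to compound 2, so among these compounds the two chains bearing a substituted amino group stand apart from both short chains, with no compound going against this. Nothing available here explains these numbers. Still open, from the compounds shown here alone, is where a carboxylic acid, a primary amine or an unsubstituted propyl chain at this sulfonyl position would fall.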